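Working notes: the step from compound 3 to compound 4

The source may report more compounds than this note shows. Statements on the series, on what has been measured and on what is new or still open speak of the compounds shown alone.

In an ADME assay on HEK293-A cells (Homo sapiens) for cytotoxicity, read by MTT assay, with a stated time of 48 h (a higher number here means a weaker inhibitor, a lower number a stronger inhibitor), compound 1 `CN(CCC#N)C[C@H]1CN(c2ccc(-n3cc(-c4ccccn4)cn3)c(F)c2)C(=O)O1` gives > 400 ug/mL, which is a limit of the assay and not a number. Compound 2 `O=C1CCC(=O)N1C[C@H]1CN(c2ccc(-n3cc(-c4ccccn4)cn3)c(F)c2)C(=O)O1` gives > 400 ug/mL, again a limit. Within the data shown here, compound 3 `O=C1CSC(=O)N1C[C@H]1CN(c2ccc(-n3cc(-c4ccccn4)cn3)c(F)c2)C(=O)O1` gives 283 ug/mL, the only actual number in the set.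

Compound 4 `CCC(=O)NC[C@H]1CN(c2ccc(-n3cc(-c4ccccn4)cn3)c(F)c2)C(=O)O1` has propanoylamino in place of 2,4-dioxo-1,3-thiazolidin-3-yl on a saturated chain carbon bound to a saturated ring carbon.

Three measured steps change this same place. The first is an at least 1.4-fold lower number from compound 1 to compound 3 (0.15 log units; that floor lies within the scatter), and the second is an at least 1.4-fold lower number from compound 2 to compound 3 (0.15 log units; that floor lies within the scatter). The third is a step that the two limits leave unreadable from compound 1 to compound 2. None of them is shown to go beyond the scatter, so the step expected in this assay is a 1.2-fold higher number from compound 3 to compound 4 (0.09 log units; within the scatter), with no expected change beyond the scatter.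

Compound 4 may be expected to return only a limit, given (the limit of > 400 ug/mL in this assay, at which 2 of the 3 values shown sit). If a number is reported, compound 4 is estimated at 350 ug/mL, with an expected range from 150 ug/mL to 800 ug/mL.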

Compound 4, half-maximal inhibitory concentration: 389 ug/mL
Estimate against measurement, compound 4: 1.1-fold (0.05 log units) below, and the stated range covers the measured number.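

In this assay, the open-chain propanoylamino group gives a second actual number at this place, on a saturated chain carbon bound to a saturated ring carbon. Replacing the 2,4-dioxo-1,3-thiazolidin-3-yl ring with this group, which adds a hydrogen-bond donor, gives a 1.4-fold higher number from compound 3 to compound 4 (0.14 log units; within the scatter). Compound 1 and compound 2 still stand only as limits of the assay, not numbers, so the steps from them give only floors, an at least 1.0-fold lower number from compound 2 to compound 4 (0.01 log units; that floor lies within the scatter) and an at least 1.0-fold lower number from compound 1 to compound 4 (0.01 log units; that floor lies within the scatter), and the limit remains common in this set: the limit of > 400 ug/mL in this assay, at which 2 of the 4 values shown sit.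

On these data alone, the step between the two limits cannot be read, so the true size of these steps stays unknown. As far as these compounds go, whether a carboxylic acid or a longer acyl chain at this place would separate from compound 3 beyond the scatter also stays open.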